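Swapping the group on the sulfonyl sulfur of compound 3

A few compounds are considered here, and "the series" means these few. Any claim that something is new, unique, unknown or untested is made for them only; others in the source may bear on it.

In a functional assay on HeLa cells (Homo sapiens) for antiproliferative activity, read by MTT assay, with a stated time of 72 h (a lower number here means a stronger inhibitor, a higher number a weaker inhibitor), compound 3 `N=C(NS(=O)(=O)c1cccc(Cl)c1)N1CCN(c2cc3c(cc2F)c(=O)c(C(=O)O)cn3C2CC2)CC1` gives 32 nM, level with compound 1 `N=C(NS(=O)(=O)c1ccccc1)N1CCN(c2cc3c(cc2F)c(=O)c(C(=O)O)cn3C2CC2)CC1` at 32 nM and compound 2 `CCn1cc(C(=O)O)c(=O)c2cc(F)c(N3CCN(C(=N)NS(=O)(=O)c4cccc(Cl)c4)CC3)cc21` at 32 nM. Compound 4 `N=C(NS(=O)(=O)c1ccccc1C(F)(F)F)N1CCN(c2cc3c(cc2F)c(=O)c(C(=O)O)cn3C2CC2)CC1` carries 2-(trifluoromethyl)phenyl in place of 3-chlorophenyl on a sulfonyl sulfur.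

Among the measured compounds shown here, two measured steps bear on this change. The closer one alters the same group on the sulfonyl sulfur: no change at the digits printed from compound 1 to compound 3 (within the scatter), with chloro in place of hydrogen on an aromatic carbon. The other, no change at the digits printed from compound 2 to compound 3 (within the scatter), has cyclopropyl in place of ethyl on an aromatic nitrogen and leaves that group untouched, so it bears only on how flat the series is so far. For the measured compounds named here, no compound with trifluoromethyl has been measured, so the evidence is indirect and the range stays wide.

The expected step is a 1.1-fold higher number from compound 3 to compound 4 (0.04 log units; within the scatter), with no shift beyond the scatter foreseen in either direction. For compound 4 the estimate is 35 nM, with an expected range of 13 nM to 95 nM.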

Compound 4, half-maximal inhibitory concentration: 32 nM
For compound 4 the middle estimate is 1.1-fold (0.04 log units) above the measured one; the range from low to high includes it.
By their numbers in this assay, from the lowest: compounds 1, 2, 3 and 4 (each within the scatter of the next).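

On the sulfonyl sulfur, 2-(trifluoromethyl)phenyl in place of 3-chlorophenyl leaves the read-out flat in this assay (no change at the digits printed from compound 3 to compound 4 (within the scatter)), and the same holds for trifluoromethyl in place of hydrogen on the aromatic carbon (no change at the digits printed from compound 1 to compound 4 (within the scatter)). The flat range at this position now extends beyond hydrogen and chloro to trifluoromethyl, and to an entering group of 10 heavy atoms against the 7 of 3-chlorophenyl. Nothing measured here accounts for this flatness.

The step from 3-chlorophenyl changes both the substituent and its place on the ring, so the contribution of each stays unresolved. Also open, on these data alone, is whether an amine or a carboxylic acid on that ring, or a straight alkyl chain in place of the ring, would shift the number beyond the scatter.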